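The compounds below may be only part of what the source reports. "The series", "measured", "known", "first", "only" and "open" are said of these compounds alone.

Measured so far:
- compound 1 `Oc1ccc(-c2cc(-c3cccc(O)c3)nc(-c3cccc(O)c3)c2)cc1`: 2230 nM
- compound 2 `Oc1cccc(-c2cc(-c3cccc(O)c3)nc(-c3ccccc3O)c2)c1`: 50000 nM
- compound 3 `Oc1cccc(-c2cc(-c3ccccc3O)cc(-c3cccc(O)c3)n2)c1`: 4570 nM

In a functional assay on T47D cells (Homo sapiens) for cytotoxicity, read by CCK-8 assay, with a stated time of 4 days (on this read-out lower numbers stand for stronger inhibition and higher numbers for weaker inhibition), compound 2 gives the highest number of the three, with compound 3 nearest and compound 1 furthest from it. The difference between the cores of compound 2 and compound 3 is not broken down here.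

From compound 3 to compound 1 the change is 4-hydroxyphenyl in place of 2-hydroxyphenyl on an aromatic carbon, placed meta to two 3-hydroxyphenyl groups and opposite the ring nitrogen; it gave a 2.0-fold lower number from compound 3 to compound 1 (0.31 log units; beyond the scatter).

Compound 4 `Oc1ccc(-c2cc(-c3cccc(O)c3)cc(-c3cccc(O)c3)n2)cc1` is not yet measured in this assay. From compound 2 to compound 4 the change is 4-hydroxyphenyl in place of 2-hydroxyphenyl on an aromatic carbon, the same kind of change, but here next to the ring nitrogen rather than opposite it. The step is expected to be a 5.0-fold lower number from compound 2 to compound 4 (0.70 log units; beyond the scatter), resting on compound 3 to compound 1 giving a 2.0-fold lower number from compound 3 to compound 1 (0.31 log units; beyond the scatter), with some extra room allowed because compound 2 gives 50000 nM. Compound 4 is therefore estimated at 10000 nM, between 2500 nM and 35000 nM.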

Compound 4, half-maximal inhibitory concentration: 3920 nM
Compound 4: middle estimate off by 2.6-fold (0.41 log units), on the high side, and the stated range covers the measured number.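

In this assay, 4-hydroxyphenyl in place of 2-hydroxyphenyl lowers the number on both cores, and the step of a 13-fold lower number from compound 2 to compound 4 (1.11 log units; beyond the scatter) is the larger of the two. The direction of the change carries from one core to the other, but its size does not: the same change on two cores in this assay, a 2.0-fold lower number (0.31 log units; beyond the scatter) from compound 3 to compound 1 and a 13-fold lower number (1.11 log units; beyond the scatter) from compound 2 to compound 4, 6.2-fold (0.79 log units) apart, beyond the scatter of two such steps.
For the compounds shown here, with only two cores compared, these results give no reason for the difference and no rule for the size of the step on a further core.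

From the compounds shown here alone, it remains open whether an aminophenyl or methoxyphenyl group in the same place would give a step of similar direction. Going by these compounds, it also remains open how a carboxylic acid in place of a hydroxyl group would read on either core.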